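Trifluoromethyl in place of methoxy: a weak growth inhibitor

The source may hold more compounds than are shown below. What is called first, only, known or untested is meant among the compounds shown, and "the series" means these compounds.

Compound 1, `Oc1cc(-c2ccccc2)nn1-c1ccc(Cl)cn1`: > 12000 nM; 19000 nM (2 entries)
Compound 2, `COc1ccc(-n2nc(-c3ccccc3)cc2O)nc1`: 25400 nM

In an ADME assay on WI-38 cells (Homo sapiens) for inhibition, read by CellTiter-Glo, with a stated time of 4 days (a higher number here means a weaker inhibitor of growth, a lower number a stronger inhibitor of growth), compound 1 gives > 12000 nM; 19000 nM (2 entries). For the measured compounds named here, compound 2 gives 25400 nM in this assay, the only number for it there, with one further entry that gave no single number. Compound 3, `Oc1cc(-c2ccccc2)nn1-c1ccc(C(F)(F)F)cn1`, differs from compound 2 by trifluoromethyl in place of methoxy on an aromatic carbon. Going by the values given here, no step between measured compounds covers this change; compound 2 and compound 1 both show weak inhibition, within the scatter of each other, and no step beyond the scatter is expected here. Compound 3 is expected at 20000 nM, with a range from 8000 nM to 50000 nM. The expected step of a 1.3-fold lower number from compound 2 to compound 3 (0.10 log units; within the scatter) lies within the scatter.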

Compound 3, concentration for 50% growth inhibition: 9400 nM
The estimate for compound 3 lay 2.1-fold (0.33 log units) above the measured number, and the stated range covers the measured number.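

In this assay, this position responds to the group it carries: trifluoromethyl in place of methoxy on an aromatic carbon gives a 2.7-fold lower number from compound 2 to compound 3 (0.43 log units; beyond the scatter), the only step shown and one beyond the scatter. Growth inhibition remains weak, with compound 3 at 9400 nM. Compound 1 has one entry that is a limit of the assay and one number, so its standing against the trifluoromethyl compound is not settled: the several entries of compound 1 in this assay, > 12000 nM; 19000 nM (2 entries)

Why the number falls remains open, as does what an amine or a carboxylic acid at this position would give.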